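From 4-methylphenyl to 4-fluorophenyl on the shared core

The source may hold more compounds than are shown below. What is called first, only, known or untested is meant among the compounds shown, and "the series" means these compounds.

In a functional assay on HCT-116 cells (Homo sapiens) for antiproliferative activity, read by MTT assay, with a stated time of 72 h (on this read-out lower numbers stand for stronger inhibition and higher numbers for weaker inhibition), compound 1 (`COc1ncc(-c2ccc3c(c2)N(c2ccc(C)cc2)C(=O)CO3)cc1NS(=O)(=O)c1ccc(F)cc1`) gives 22700 nM and compound 2 (`COc1ccc(N2C(=O)COc3ccc(-c4cnc(Cl)c(NS(=O)(=O)c5ccc(F)cc5)c4)cc32)cc1`) gives 30100 nM as its number. These two values lie within the scatter of each other, so compound 1 stands level with compound 2 and no order can be drawn between them.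

Compound 3 (`COc1ncc(-c2ccc3c(c2)N(c2ccc(F)cc2)C(=O)CO3)cc1NS(=O)(=O)c1ccc(F)cc1`) keeps the core of compound 1 and changes a single group (fluoro in place of methyl on an aromatic carbon). This places fluoro in place of methyl on an aromatic carbon, para to a large group, so that 4-methylphenyl becomes 4-fluorophenyl.

Among the compounds with values here, no measured pair shows a change at this place, so the step has no direct precedent. The expectation rests on compound 1 at 22700 nM as the starting point, and no change beyond the scatter is expected. The estimated step is a 1.1-fold higher number from compound 1 to compound 3 (0.04 log units; within the scatter) and it is expected to stay within the scatter, with only a slight lean towards a higher number.

For compound 3 the expected value is 25000 nM with an estimated range from 10000 nM to 60000 nM for this compound.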

Compound 3, half-maximal inhibitory concentration: > 40000 nM
Compound 3: no number, only a limit; the forecaster's own chance of this, stated with the estimate: 15%; middle value at least 1.6-fold (0.20 log units) away from the limit.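

In this assay compound 3 gives > 40000 nM, which is a limit of the assay and not a number. Within the data shown here, this is the first reading for a change on this aromatic carbon, para to a large group, and the step is an at least 1.7-fold higher number from compound 1 to compound 3 (0.24 log units; that floor lies within the scatter): fluoro in place of methyl gives no sign of a lower number here, but the floor of the step stays within the scatter, so neither a real loss nor its size is established. The reading is bounded on one side only: the limit of > 40000 nM in this assay, at which 1 of the 3 values shown sits.

Among these compounds, compound 2 differs from compound 1 in more than one place, so it adds no step for this position, and the effect of the methyl-to-fluoro change remains a single open-ended comparison on one core. On these data alone, whether an amine or a carboxylic acid at this carbon would give a number clearly apart from that of compound 1 stays open, and so does the actual value of compound 3 beyond its limit.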